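This account rests on a few compounds, and the source may have more. Where it says the series, first, only, none or still open, it means among the compounds named here.

Measured in an ADME assay on the whole organism (serum) with Homo sapiens as the target; a higher number here means that the compound lasts longer, a lower number that the compound disappears faster
Compound 1 `Cc1cn(C2CC(N=[N+]=[N-])C(COC(=O)OCCCCCCCCO)O2)c(=O)[nH]c1=O` gives 0.0333 h
Compound 2 `Cc1cn(C2CC(N=[N+]=[N-])C(COC(=O)NCCCO)O2)c(=O)[nH]c1=O` gives > 48 h
Compound 3 `Cc1cn(C2CC(N=[N+]=[N-])C(COC(=O)OCCCCCCO)O2)c(=O)[nH]c1=O` gives 0.117 h

The entry for compound 2 is a limit of the assay and not a number. Within the data shown here, of the two true numbers in this assay compound 3 has the higher, and the gap between them is a 3.5-fold higher number from compound 1 to compound 3 (0.55 log units; beyond the scatter) as the only step between numbers.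

Next is compound 4 `Cc1cn(C2CC(N=[N+]=[N-])C(COC(=O)NCCCC(=O)O)O2)c(=O)[nH]c1=O` with the change (3-carboxypropyl)amino in place of (6-hydroxyhexyl)oxy on a carbonyl carbon which puts (3-carboxypropyl)amino in place of (6-hydroxyhexyl)oxy on a carbonyl carbon. Two measured steps exchange an oxy group and an amino group at this place, both large and beyond the scatter. The expectation rests on compound 2 alone, through an at least 1400-fold higher number from compound 1 to compound 2 (3.15 log units; beyond the scatter) and an at least 410-fold lower number from compound 2 to compound 3 (2.61 log units; beyond the scatter) in the opposite sense. Among the measured compounds shown here, no measured compound carries the carboxy end. A large rise in this assay is therefore expected, quite possibly reaching the limit of the assay. The expected step is a 410-fold higher number from compound 3 to compound 4 (2.61 log units; beyond the scatter) as estimated here. For compound 4 the estimated half-life is 48 h with an expected range from 12 h to 150 h at this stage.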

Compound 4, half-life: > 48 h
Compound 4: only a limit was reported; the forecaster's own chance of this, stated with the estimate: 65%; the middle value lies on the limit itself.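

In this assay the (3-carboxypropyl)amino group on this carbonyl carbon stands well apart from both oxy-linked compounds, with an at least 410-fold higher number from compound 3 to compound 4 (2.61 log units; beyond the scatter) and an at least 1400-fold higher number from compound 1 to compound 4 (3.15 log units; beyond the scatter), so the amino-linked result of compound 2 is no longer a single case and holds with a carboxy end as well as a hydroxy end. Compound 4 gives > 48 h, which is a limit of the assay and not a number. The change from hydroxy to carboxy between compound 2 and compound 4 cannot be read, as both entries are limits: the limit of > 48 h in this assay, at which 2 of the 4 values shown sit.

Going by these compounds, how much of the rise belongs to the amino link and how much to the shorter chain stays open, and a (6-hydroxyhexyl)amino group at this place would separate the two. On these data alone, a primary amine at the chain end, or a longer chain ending in carboxy, is also open.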